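Triethoxybenzamide series: aryl group at the chloro-bearing ring

The source may hold more compounds than are shown below. What is called first, only, known or untested is meant among the compounds shown, and "the series" means these compounds.

Measured so far:
- compound 1 `CCOc1cc(C(=O)Nc2ccc(Cl)c(-c3nc4ccccc4s3)c2)cc(OCC)c1OCC`: "not active" (no number reported)
- compound 2 `CCOc1cc(C(=O)Nc2ccc(Cl)c(C3=NCCN3)c2)cc(OCC)c1OCC`: "not active" (no number reported)
- compound 3 `N#Cc1ccc(C(=O)Nc2ccc(Cl)c(-c3nc4ccccc4[nH]3)c2)cc1`: 185 nM

In a functional assay on Shh Light II cells for inhibition of Sonic hedgehog protein (Mus musculus), read by reporter gene assay, with a stated time of 48 h, in the presence of a further agent that is not named here (on this read-out higher numbers stand for weaker inhibition and lower numbers for stronger inhibition), compound 1 gives "not active" (no number reported). In this assay compound 2 gives "not active" (no number reported), so compound 2 has no single number; one further compound, compound 1, likewise carries no single number, and only compound 3 has a value. In this assay compound 3 gives 185 nM. Compound 4 `CCOc1cc(C(=O)Nc2ccc(Cl)c(-c3nc4ccccc4o3)c2)cc(OCC)c1OCC` has not been measured yet. It differs from compound 2 in one place: a group of 9 heavy atoms (7 carbon, 1 nitrogen, 1 oxygen; one five-membered aromatic ring with 2 hetero atoms, one six-membered aromatic ring of carbon only) in place of a group of 5 heavy atoms (3 carbon, 2 nitrogen; one five-membered non-aromatic ring with 2 hetero atoms), on an aromatic carbon, the change sitting on an aromatic carbon ortho to a chloro group and meta to a large group. Among the compounds with values here, no step between measured compounds is available, so nothing can be said about its size from a measured pair. Both compound 1 and compound 2, which share the triethoxy benzamide of compound 4, are without a number; on that basis compound 4 is expected to remain weak, and the estimate for compound 4 is 8000 nM with a range from 1000 nM to 50000 nM.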

Compound 4, half-maximal inhibitory concentration: "not active" (no number reported)
No number was reported for compound 4, and the estimate cannot be compared.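

In this assay compound 2 gives "not active" (no number reported) and compound 4 gives "not active" (no number reported), so no step can be read between them. No measured evidence bears on this result. The compounds shown leave open whether the 1,3-benzoxazol-2-yl group would give a number on any other benzamide.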